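A few compounds are considered here, and "the series" means these few. Any claim that something is new, unique, unknown or untested is made for them only; others in the source may bear on it.

Going by the values given here, in a functional assay on SJSA-1 cells (Homo sapiens) for antiproliferative activity, read by fluorescence, with a stated time of 72 h (on this read-out higher numbers stand for weaker inhibition and lower numbers for stronger inhibition), compound 1 `O=C(O)c1nc(-c2ccccc2)n(-c2cccc(Cl)c2F)c1-c1ccc(F)c(Cl)c1` gives 14000 nM, the lowest of the two numbers measured so far. Compound 2 `Cc1ccc(Cl)cc1-n1c(-c2ccccc2)nc(C(=O)O)c1-c1cccc(Cl)c1` gives 16100 nM in this assay, and the two values lie within the usual scatter of each other, so neither can be called the stronger of the pair. Compound 3 `O=C(O)c1nc(C2CCCCC2)n(-c2cccc(Cl)c2F)c1-c1ccc(F)c(Cl)c1` has not yet been measured. It differs from compound 1 in one place: cyclohexyl in place of phenyl on an aromatic carbon. Among the compounds with values here, no pair of measured compounds shows what a change of this kind does in this assay, so the size and direction of the step can only be guessed. A modest move toward stronger inhibition seems plausible but is far from certain. Compound 3 is expected to give about 8000 nM in this assay, with a likely range from 2000 nM to 30000 nM. The expected step from compound 1 to compound 3 is a 1.8-fold lower number from compound 1 to compound 3 (0.24 log units; within the scatter), estimated as small and close to the scatter.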

Compound 3, half-maximal inhibitory concentration: 13200 nM
Compound 3: middle estimate off by 1.7-fold (0.22 log units), on the low side, and the stated range covers the measured number.
By their numbers in this assay, from the lowest: compounds 3, 1 and 2 (each within the scatter of the next).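

Exchanging the phenyl on the aromatic carbon between two ring nitrogen atoms for cyclohexyl gives a 1.1-fold lower number from compound 1 to compound 3 (0.03 log units; within the scatter) in this assay, so the two compounds cannot be told apart on this read-out. At this position, then, a six-membered aromatic ring of carbon only and a six-membered non-aromatic ring of carbon only, each with the same count of heavy atoms, give numbers within the scatter of each other. No measurement at hand explains why this exchange leaves the two compounds indistinguishable. The compounds shown leave open whether a much smaller group at this position, such as methyl, or a ring carrying an amine, such as piperidinyl, would move the number clearly away from that of compound 1. They also leave open whether cyclohexyl would behave the same way alongside the aryl groups of compound 2.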